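Aryl change at the limit of the assay

The source may hold more compounds than are shown below. What is called first, only, known or untested is meant among the compounds shown, and "the series" means these compounds.

In a functional assay on KYSE-70 cells for antiproliferative activity against KYSE-70 cell line (Homo sapiens), read by MTT assay, with a stated time of 72 h (a higher number here means a weaker inhibitor, a lower number a stronger inhibitor), compound 1 `O=C(Nc1cc(F)ccc1F)c1cc(=O)[nH]c2cc(Br)ccc12` gives > 20000 nM, which is a limit and not a number. Compound 2 `Cc1ccc(-c2ccc3c(C(=O)Nc4cccc(F)c4)cc(=O)[nH]c3c2)cc1` gives > 20000 nM in this assay, again a limit. The series therefore stands at the limit of > 20000 nM in this assay, at which 2 of the 2 values shown sit, and compound 2 offers no number of its own to step from. Compound 3 `O=C(Nc1cccc(F)c1)c1cc(=O)[nH]c2cc(-c3ccc(F)c(CO)c3)ccc12` keeps the core of compound 2 and carries 4-fluoro-3-(hydroxymethyl)phenyl in place of 4-methylphenyl on an aromatic carbon. Since the limit for compound 2 is > 20000 nM, only a modest move toward a stronger inhibitor is expected, and a further limit remains quite possible. The estimated size of the change is an at least 1.4-fold lower number from compound 2 to compound 3 (0.15 log units; that floor lies within the scatter). For compound 3 the expected value is 14000 nM, with an estimated range of 4000 nM to 40000 nM.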

Compound 3, half-maximal inhibitory concentration: > 20000 nM
Compound 3: a limit, no number (the forecaster's own chance of this, stated with the estimate: 55%); middle value at least 1.4-fold (0.15 log units) away from the limit.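

Compound 2 and compound 3 both sit at a limit in this assay, so no step can be read between them. The series stands as follows: the limit of > 20000 nM in this assay, at which 3 of the 3 values shown sit.

The compounds shown leave open which change to the shared core, if any, would give a measurable number.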